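From ethyl to methoxy: working notes on compound 4

This account rests on a few compounds, and the source may have more. Where it says the series, first, only, none or still open, it means among the compounds named here.

Of the compounds shown here, three sharing one core have been measured in a functional assay on MDA-MB-231 cells (Homo sapiens) for antiproliferative activity, read by spectrophotometry and resazurin assay, with a stated time of 72 h; a higher number here means a weaker inhibitor, a lower number a stronger inhibitor. Compound 1 (`O=C(CC1Oc2cc(O)ccc2C=C1c1ccc(O)cc1)c1ccccc1`) gives 88000 nM. Compound 2 (`Cc1ccc(C(=O)CC2Oc3cc(O)ccc3C=C2c2ccc(O)cc2)cc1`) gives 55000 nM, and the methyl in place of hydrogen amounts to a 1.6-fold lower number from compound 1 to compound 2 (0.20 log units; within the scatter). Compound 3 (`CCc1ccc(C(=O)CC2Oc3cc(O)ccc3C=C2c2ccc(O)cc2)cc1`) gives 198000 nM, the highest number of the three and so the weakest inhibitor so far. It stands apart from both neighbours: a 2.3-fold higher number from compound 1 to compound 3 (0.35 log units; beyond the scatter) and a 3.6-fold higher number from compound 2 to compound 3 (0.56 log units; beyond the scatter).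

Compound 4 (`COc1ccc(C(=O)CC2Oc3cc(O)ccc3C=C2c2ccc(O)cc2)cc1`) carries methoxy in place of ethyl on an aromatic carbon. Going by the values given here, no measured compound carries methoxy, so the data give no direct step for this change. The closest guide is the pair of steps that lead to the ethyl compound, a 2.3-fold higher number from compound 1 to compound 3 (0.35 log units; beyond the scatter) and a 3.6-fold higher number from compound 2 to compound 3 (0.56 log units; beyond the scatter). Replacing the ethyl is expected to give up part or all of that rise, which would return the number towards the region held by compound 1 and compound 2. A modest step to a lower number is therefore expected in this assay, though with low confidence. The estimated change is a 2.2-fold lower number from compound 3 to compound 4 (0.34 log units; beyond the scatter). For compound 4 the expected value is 90000 nM, with an estimated range of 40000 nM to 200000 nM.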

Compound 4, half-maximal inhibitory concentration: 7600 nM
Beside the measured number, compound 4's estimate is 12-fold (1.07 log units) above it; the measured number lies below the stated range.
By their numbers in this assay, from the lowest: compound 4; then compounds 2 and 1 (each within the scatter of the next); then compound 3.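

Until now this position, the aromatic carbon para to a large group, had shown only a step within the scatter for methyl and a rise for ethyl, so methoxy is the first group here to bring the number clearly below that of the unsubstituted compound, with a 12-fold lower number from compound 1 to compound 4 (1.06 log units; beyond the scatter) and a 7.2-fold lower number from compound 2 to compound 4 (0.86 log units; beyond the scatter) in this assay. The exchange of ethyl for methoxy leaves the count at 2 heavy atoms, replaces one carbon with one oxygen and adds one hydrogen-bond acceptor, yet it gives a 26-fold lower number from compound 3 to compound 4 (1.42 log units; beyond the scatter), the largest step among these four compounds. Size counted in heavy atoms therefore does not set the number at this position, since two groups of equal count lie at opposite ends of the series.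

No measurement available here accounts for the drop from ethyl to methoxy. On these data alone, whether it belongs to the oxygen itself or to the whole methoxy group stays open, and a hydroxyl, an ethoxy group or a dimethylamino group at the same carbon would help to separate the two.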